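Swapping the Aryl Group in Dihydrofolate Reductase Inhibitors

The compounds below may be only part of what the source reports. "The series", "measured", "known", "first", "only" and "open" are said of these compounds alone.

Compound 1 `NC1=NC2(CCOCC2)N(OCCCOc2cccc(Cl)c2)C(N)=N1`: 83.2% in an assay on isolated protein for inhibition of Dihydrofolate reductase (Homo sapiens), read by spectrophotometry, using NADPH, with stated times of 5 s and 6 min, tested at 5 uM; on this read-out higher numbers stand for a stronger effect at the one concentration tested and lower numbers for a weaker effect
Compound 2 `NC1=NC2(CCOCC2)N(OCCCOc2cccc(Cl)c2Cl)C(N)=N1`: 81.7%
Compound 3 `NC1=NC2(CCOCC2)N(OCCCOc2ccc(Br)cc2)C(N)=N1`: > 90%

Compound 3 stands at a limit of the assay rather than at a number, (the limit of > 90% in this assay, at which 1 of the 3 values shown sits), so where it truly lies is not known. Compound 4 `Cc1cc(C)cc(OCCCON2C(N)=NC(N)=NC23CCOCC3)c1` differs from compound 3 by the change (3,5-dimethylphenyl in place of 4-bromophenyl on an oxygen on a saturated carbon). The two measured steps that exchange the same aryl group, a number at least 6.8 percentage points higher from compound 1 to compound 3 (that floor lies within the scatter) and a number at least 8.3 percentage points higher from compound 2 to compound 3 (that floor lies within the scatter), both have floors within the scatter, and a number 1.5 percentage points lower from compound 1 to compound 2 (within the scatter) also lies within it. No shift beyond the scatter is therefore expected in this assay. Compound 4 is expected to give 86%, between 72% and 95%. The estimated step of a number at least 4 percentage points lower from compound 3 to compound 4 (that floor lies within the scatter) is expected to stay within the scatter.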

Compound 4, a percentage reported as inhibition, at one concentration (the size of the read-out at that concentration, not a potency): 84.3%
Compound 4: middle estimate off by 1.7 percentage points, on the high side, and the stated range covers the measured number.
By their numbers in this assay, from the lowest: compounds 2, 1 and 4 (each within the scatter of the next). At a limit, above all of these: compound 3.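

In this assay, 3,5-dimethylphenyl, which carries no halogen, reads much like the chlorinated aryl groups at this place: a number 1.1 percentage points higher from compound 1 to compound 4 (within the scatter) and a number 2.6 percentage points higher from compound 2 to compound 4 (within the scatter). So a halogen on the ring is not needed for a high read-out here. Against 4-bromophenyl the reading is a number at least 5.7 percentage points lower from compound 3 to compound 4 (that floor lies within the scatter), and only a floor can be given for that step: the limit of > 90% in this assay, at which 1 of the 4 values shown sits.

The compounds shown leave open whether any aryl group is needed, since an amine or a carboxylic acid in its place would test this directly. One concentration also gives no potency to rank them by.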